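From Diethylamino to Diisopropylamino on a Carbonyl Carbon

The source may report more compounds than this note shows. Statements on the series, on what has been measured and on what is new or still open speak of the compounds shown alone.

In a functional assay on MCF7 cells (Homo sapiens) for antiproliferative activity, read by MTT assay, with a stated time of 48 h (on this read-out higher numbers stand for weaker inhibition and lower numbers for stronger inhibition), compound 1 (`CSC(=S)OC/C1=C/C[C@](C)(CCC=C(C)C)/C=C/[C@@H](OC(=O)C=C(C)C)[C@](C)(O)/C=C/C1=O`) gives 900 nM, while compound 2 (`CCN(CC)C(=O)/C1=C/C[C@](C)(CCC=C(C)C)/C=C/[C@@H](OC(=O)C=C(C)C)[C@](C)(O)/C=C/C1=O`) gives 12100 nM, the higher of the two numbers. Compound 3 (`CC(C)=CCC[C@]1(C)/C=C/[C@@H](OC(=O)C=C(C)C)[C@](C)(O)/C=C/C(=O)/C(C(=O)N(C(C)C)C(C)C)=C\C1`) differs from compound 2 in one place: diisopropylamino in place of diethylamino on a carbonyl carbon. Among the measured compounds shown here, the only measured step, a 13-fold higher number from compound 1 to compound 2 (1.13 log units; beyond the scatter), is large, but it exchanged a different group, so it offers little guide to this change. For the measured compounds named here, no measured step covers this exchange, so no shift beyond the scatter is expected in this assay. The estimated step is a 1.1-fold higher number from compound 2 to compound 3 (0.03 log units; within the scatter). Compound 3 is expected at 13000 nM, within a range of 5000 nM to 30000 nM.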

Compound 3, half-maximal inhibitory concentration: 17200 nM
Compound 3: middle estimate off by 1.3-fold (0.12 log units), on the low side; the range from low to high includes it.
By their numbers in this assay, from the lowest: compound 1; then compounds 2 and 3 (each within the scatter of the next).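

Exchanging diethylamino for diisopropylamino on this carbonyl carbon gives a 1.4-fold higher number from compound 2 to compound 3 (0.15 log units; within the scatter) in this assay, so the two amine groups cannot be told apart at this position. The larger gap to the group in compound 1 remains, with a 19-fold higher number from compound 1 to compound 3 (1.28 log units; beyond the scatter), which places compound 3 on the weaker side of compound 1, as compound 2 is. Nothing available explains these numbers. Open, from the compounds shown here alone, is how a smaller amine such as dimethylamino, or a ring amine such as piperidine, would read on this carbonyl carbon. Going by these compounds, a free carboxylic acid there is equally open.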